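A thioether on the aryl ring: what to expect for compound 4

The compounds below may be only part of what the source reports. "The series", "measured", "known", "first", "only" and "open" are said of these compounds alone.

Three compounds share one core and differ only in the aryl group carried on the unsaturated amide chain. Compound 1 `CCCc1cc(N)c2cc(NC(=O)/C=C/c3ccc(C(C)(C)C)cc3)ccc2n1` gives 910 nM in a functional assay on HEK293 cells for activation of melanin-concentrating hormone receptor 1 (Homo sapiens), read by inositol phosphate accumulation; a lower number here means that less compound is needed, a higher number that more compound is needed for the effect. Compound 2 `CCCc1cc(N)c2cc(NC(=O)/C=C/c3ccc(C(C)C)cc3)ccc2n1` gives 520 nM, and compound 3 `CCCc1cc(N)c2cc(NC(=O)/C=C/c3ccccc3Cl)ccc2n1` gives 500 nM. The change a 1.8-fold lower number from compound 1 to compound 2 (0.24 log units; within the scatter) and the change a 1.0-fold lower number from compound 2 to compound 3 (0.02 log units; within the scatter) both stay inside the normal measurement scatter, so on the numbers shown compound 3 sits at the low end of the three without being separable from compound 1 or compound 2.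

Compound 4 `CCCc1cc(N)c2cc(NC(=O)/C=C/c3ccc(SC)cc3)ccc2n1` carries the change (4-(methylsulfanyl)phenyl in place of 2-chlorophenyl on a double-bonded chain carbon bound to a double-bonded chain carbon). Both measured steps bear on this one, since each also swaps the aryl group on the same chain carbon, and neither moved the number beyond the scatter. Nothing in the data suggests that a third swap of this kind should behave differently, so the expected step is a 1.2-fold higher number from compound 3 to compound 4 (0.08 log units; within the scatter), that is, no shift beyond the scatter. Compound 4 is therefore estimated at 600 nM in this assay, with a plausible range from 250 nM to 1500 nM.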

Compound 4, half-maximal effective concentration: 71 nM
Compound 4: the middle estimate sits 8.5-fold (0.93 log units) above what was measured, outside the stated range (below it).
By their numbers in this assay, from the lowest: compound 4; then compounds 3, 2 and 1 (each within the scatter of the next).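

In this assay, within the data shown here, the aryl group on this chain carbon turns out to matter: the swap to 4-(methylsulfanyl)phenyl gives a 7.0-fold lower number from compound 3 to compound 4 (0.85 log units; beyond the scatter) and is the first aryl change to lie beyond the scatter. The comparison with the two alkyl-bearing aryl groups points the same way, with methylsulfanyl in place of isopropyl on the aromatic carbon giving a 7.3-fold lower number from compound 2 to compound 4 (0.86 log units; beyond the scatter) and methylsulfanyl in place of tert-butyl on that carbon giving a 13-fold lower number from compound 1 to compound 4 (1.11 log units; beyond the scatter) as the largest step of the set. So the three earlier aryl groups could not be told apart from one another, yet compound 4 separates clearly from each of them, and the drop does not depend on which earlier compound serves as the reference.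

Nothing shown here offers any measured explanation for why the number falls this far. On these data alone, it also stays open whether the sulfur atom itself counts or any small group of this length would do, a question that a methoxy group or an ethylsulfanyl chain on the same aromatic carbon would address.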